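Chain Extension on the Methyl-Bearing Core

The compounds below may be only part of what the source reports. "The series", "measured", "known", "first", "only" and "open" are said of these compounds alone.

Of the compounds shown here, three built on one shared core have been tested in a functional assay on HepG2 cells (Homo sapiens) for cytotoxicity; a higher number here means a weaker inhibitor, a lower number a stronger inhibitor. Compound 1 `N#C/N=C1\N(CCCCCOc2ccc(Cl)cc2)C(=O)CN1c1ccncc1` gives 4200 nM. Compound 2 `N#C/N=C1\N(CCCCCCOc2ccc(Cl)cc2)C(=O)CN1c1ccncc1` gives 392 nM. Compound 3 `CC1C(=O)N(CCCCCOc2ccc(Cl)cc2)/C(=N\C#N)N1c1ccncc1` gives 4090 nM. On the numbers shown, compound 3 stands second highest of the three, with compound 1 nearest at a gap that is within the scatter and compound 2 furthest, at a gap beyond the scatter.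

Two steps among the measured compounds are relevant. The step of a 1.0-fold lower number from compound 1 to compound 3 (0.01 log units; within the scatter) shows that adding the methyl on the saturated ring carbon leaves this assay essentially unchanged. The step of an 11-fold lower number from compound 1 to compound 2 (1.03 log units; beyond the scatter) shows that lengthening the chain on the unmethylated core produces a large drop.

Compound 4 `CC1C(=O)N(CCCCCCOc2ccc(Cl)cc2)/C(=N\C#N)N1c1ccncc1` differs from compound 3 by (4-chlorophenoxy)methyl in place of 4-chlorophenoxy on a saturated chain carbon, five bonds along the chain from an amide-type nitrogen in a ring. This is the same chain change that separates compound 1 from compound 2, now applied to the methyl-bearing core. Since the methyl itself did nothing measurable in a 1.0-fold lower number from compound 1 to compound 3 (0.01 log units; within the scatter), a step of similar size to an 11-fold lower number from compound 1 to compound 2 (1.03 log units; beyond the scatter) is expected, giving a 10-fold lower number from compound 3 to compound 4 (1.01 log units; beyond the scatter). Compound 4 is therefore estimated at 400 nM in this assay, with a range from 150 nM to 1100 nM.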

Compound 4, half-maximal inhibitory concentration: 282 nM
For compound 4 the middle estimate is 1.4-fold (0.15 log units) above the measured one; measured number inside the range.
By their numbers in this assay, from the lowest: compounds 4 and 2 (each within the scatter of the next); then compounds 3 and 1 (each within the scatter of the next).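

The change from 4-chlorophenoxy to (4-chlorophenoxy)methyl gives a 15-fold lower number from compound 3 to compound 4 (1.16 log units; beyond the scatter) in this assay, so the large step first seen on the unmethylated core recurs on the methyl-bearing core, at a closely matching size: the same change on two cores in this assay, an 11-fold lower number (1.03 log units; beyond the scatter) from compound 1 to compound 2 and a 15-fold lower number (1.16 log units; beyond the scatter) from compound 3 to compound 4, 1.4-fold (0.13 log units) apart, within the scatter of two such steps

The methyl on the saturated ring carbon had so far been read only with 4-chlorophenoxy at the chain position, and with (4-chlorophenoxy)methyl there it gives a 1.4-fold lower number from compound 2 to compound 4 (0.14 log units; within the scatter), which leaves it without a measurable effect in both settings: the same change on two cores in this assay, a 1.0-fold lower number (0.01 log units; within the scatter) from compound 1 to compound 3 and a 1.4-fold lower number (0.14 log units; within the scatter) from compound 2 to compound 4, 1.4-fold (0.13 log units) apart, within the scatter of two such steps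

Across these four compounds, the two changes therefore act as if independent of each other, with the chain change alone separating compounds 2 and 4 from compounds 1 and 3, and no compound shown goes against this.

Among these compounds, still open is whether 2-(4-chlorophenoxy)ethyl at the same place would carry the trend further or reverse it, since only one such step can be read on each core. Going by these compounds, it is also open whether a larger group such as ethyl on the saturated ring carbon, or an amine within the chain, would leave the number in this assay as unchanged as the methyl does or shift it.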